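Swapping chloro for fluoro on two different cores

The source may report more compounds than this note shows. Statements on the series, on what has been measured and on what is new or still open speak of the compounds shown alone.

Compound 1 `Cc1cc(C)c2c(O)cc(-c3cccc(F)c3)nc2n1` and compound 2 `Cc1cc(C)c2c(O)cc(-c3cccc(Cl)c3)nc2n1` share a core and differ only in the halogen on the pendant aromatic ring. In a functional assay on MDA-N cells (Homo sapiens) for antiproliferative activity (on this read-out higher numbers stand for weaker inhibition of growth and lower numbers for stronger inhibition of growth), compound 1 gives 12.9 nM, and in this assay compound 2 gives 19.1 nM. The change between them, (fluoro in place of chloro on an aromatic carbon), made a step of a 1.5-fold lower number from compound 2 to compound 1 (0.17 log units; within the scatter).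

Compound 3 `Cc1cnc2[nH]c(-c3cccc(Cl)c3)cc(=O)c2c1` carries the same chloro-bearing aromatic ring on a different core; the difference between the two cores is not broken down here. In this assay compound 3 gives only a limit, > 100000 nM, and that limit is the limit of > 100000 nM in this assay, at which 1 of the 3 values shown sits.

Compound 4 `Cc1cnc2[nH]c(-c3cccc(F)c3)cc(=O)c2c1` is the fluoro counterpart of compound 3, and the change is fluoro in place of chloro on an aromatic carbon. The two places described for this change are the same word for word, so it is the same change as that from compound 2 to compound 1. Since that change produced a step within the scatter, the expectation for compound 4 is a step of a number no higher from compound 3 to compound 4 (the limit leaves the size open), resting on the step of a 1.5-fold lower number from compound 2 to compound 1 (0.17 log units; within the scatter) and on the limit of compound 3. Compound 4 is therefore estimated at 100000 nM, with a range from 30000 nM to 300000 nM, and it is expected that this assay will most likely again report only a limit rather than a number.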

Compound 4, concentration for 50% growth inhibition: 11.8 nM
For compound 4 the middle estimate is 8500-fold (3.93 log units) above the measured one; the measured number lies below the stated range.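

In this assay, the swap of chloro for fluoro on the core of compound 3 gives an at least 8400-fold lower number from compound 3 to compound 4 (3.92 log units; beyond the scatter), so the size of the step did not carry over from one core to the other: the same change on two cores in this assay, a 1.5-fold lower number (0.17 log units; within the scatter) from compound 2 to compound 1 and an at least 8400-fold lower number (3.92 log units; beyond the scatter) from compound 3 to compound 4, at least 5700-fold (3.75 log units) apart, beyond the scatter of two such steps The size of the new step is only a lower bound, as compound 3 gives a limit of the assay and not a number: the limit of > 100000 nM in this assay, at which 1 of the 4 values shown sits. The two pairs show that in this series the same halogen swap can leave the read-out within the scatter on one core and shift it far beyond the scatter on another, but they do not show what in the cores separates the two outcomes, nor do two pairs give a rule for any further core.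

The compounds shown carry only chloro and fluoro on the pendant aromatic ring, which leaves open how a methoxy group, an amine or a carboxylic acid in that place would read on either core. As far as these compounds go, it also remains open which of the differences between the two cores goes with the gap between the steps, and whether another halogen such as bromo would follow the fluoro or the chloro compound on the core of compound 3.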